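Shortening an Ethyl Side Chain in a Hydroxamic Acid Series

A few compounds are considered here, and "the series" means these few. Any claim that something is new, unique, unknown or untested is made for them only; others in the source may bear on it.

Measured so far:
compound 1, `CCc1cc(-c2ccc(F)cc2)nn1Cc1ccc(C(=O)NO)cc1`: 16700 nM
compound 2, `O=C(CCCCCNC(=O)c1cc(-c2ccc(F)cc2)[nH]n1)NO`: 47600 nM

Both compounds were tested in a functional assay on HepG2 cells (Homo sapiens) for antiproliferative activity, read by MTT assay, with a stated time of 96 h; on this read-out lower numbers stand for stronger inhibition of growth and higher numbers for weaker inhibition of growth. Compound 1 gives 16700 nM, the lowest of the two numbers. Compound 2 gives 47600 nM, a higher number that lies beyond the scatter of such measurements, so compound 1 is the stronger growth inhibitor of the pair.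

The next compound, compound 3, `Cc1cc(-c2ccc(F)cc2)nn1Cc1ccc(C(=O)NO)cc1`, has not yet been measured. It differs from compound 1 in one place: hydrogen in place of methyl on a saturated chain carbon bound to an aromatic carbon. Cut one bond further out, the same difference reads ethyl to methyl, a small trimming of the side chain on the shared core.

For the measured compounds named here, no measured pair shows what such a trimming does here. Because compound 1 gives 16700 nM and the change is so small, the step of a 1.1-fold higher number from compound 1 to compound 3 (0.03 log units; within the scatter) is expected to stay within the scatter, in no clear direction. Compound 3 is therefore estimated at 18000 nM, with a range from 8000 nM to 40000 nM.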

Compound 3, concentration for 50% growth inhibition: 30000 nM
For compound 3 the middle estimate is 1.7-fold (0.22 log units) below the measured one; low and high end bracket the measured number.
By their numbers in this assay, from the lowest: compounds 1, 3 and 2 (each within the scatter of the next, the first and the last beyond it).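

For the compounds shown here, compounds 1 and 3 form the first pair here that differ in one place only, so the effect of this side chain can be read directly: in this assay, cutting ethyl to methyl gives a 1.8-fold higher number from compound 1 to compound 3 (0.25 log units; within the scatter) and so produces no clear change. At this position, on a saturated chain carbon bound to an aromatic carbon, ethyl and methyl cannot be told apart by growth inhibition in these cells. No supporting measurement is available to explain this result.

A single small step does not show how far this tolerance extends, and a longer chain such as butyl, or an amine at the end of the chain, could still move the number beyond the scatter. Going by these compounds, whether ethyl and methyl would also match on a different core remains open.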